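Piperazine in place of methylamide on a kinase inhibitor

This account rests on a few compounds, and the source may have more. Where it says the series, first, only, none or still open, it means among the compounds named here.

Of the compounds shown here, three sharing one core have been measured in an assay on isolated protein for inhibition of MAP kinase-interacting serine/threonine-protein kinase 2 (Homo sapiens), read by HTRF, in the presence of a further agent that is not named here; on this read-out lower numbers stand for stronger inhibition and higher numbers for weaker inhibition. Compound 1, `CNC(=O)c1cccc(C#Cc2ccccc2Nc2ncnc3ccc(Cl)nc23)c1`, gives 4900 nM, the highest number of the three and therefore the weakest inhibition among them. Compound 3, `Cc1c(C(=O)N2CCOCC2)oc2ccc(Nc3ncnc4ccc(Cl)nc34)cc12`, gives 1800 nM, and compound 2, `N#Cc1ccc(Nc2ncnc3ccc(-c4ccc(C(=O)N5CCNCC5)cc4)nc23)cc1`, gives 43 nM. Both of these lie beyond the scatter away from compound 1.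

Compound 4, `O=C(c1cccc(C#Cc2ccccc2Nc2ncnc3ccc(Cl)nc23)c1)N1CCNCC1`, has not yet been measured. It differs from compound 1 in a single place: piperazin-1-yl in place of methylamino on a carbonyl carbon. Compound 2 also carries a piperazin-1-yl group on a carbonyl carbon, yet its other parts differ from those of compound 1 as well, so its value cannot be read as a measure of this one change. Going by the values given here, no measured pair isolates the change, so the expectation rests on compound 1 alone. The step from compound 1 to compound 4 is expected to be a modest lowering of the number, a 2.0-fold lower number from compound 1 to compound 4 (0.29 log units; within the scatter), possibly no larger than the scatter. Compound 4 is therefore estimated at 2500 nM, with a range from 700 nM to 9000 nM.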

Compound 4, half-maximal inhibitory concentration: 5000 nM
The estimate for compound 4 lay 2.0-fold (0.30 log units) below the measured number; measured number inside the range.
By their numbers in this assay, from the lowest: compound 2; then compound 3; then compounds 1 and 4 (each within the scatter of the next).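

In this assay, going by these compounds alone, this is the first pair that isolates a single change at this carbonyl carbon: a 1.0-fold higher number from compound 1 to compound 4 (0.01 log units; within the scatter), which lies within the usual scatter. Replacing methylamino with piperazin-1-yl adds a six-membered non-aromatic ring and more heavy atoms at this position, yet the two compounds cannot be told apart on this read-out. The data shown include no measurement that could explain this match.

On these data alone, it remains open whether dimethylamino, or a longer chain ending in an amine, on the same carbonyl carbon would give a number that differs beyond the scatter. As far as these compounds go, it also remains open whether the swap from methylamino to piperazin-1-yl would give a similar result on another core, as this single pair speaks only for the core of compound 1.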